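Chloro for nitrile on the lactam-bearing ring

The compounds below may be only part of what the source reports. "The series", "measured", "known", "first", "only" and "open" are said of these compounds alone.

Three compounds of this series share one core and differ only in the group on an aromatic carbon of the lactam-bearing ring. In an assay on COS-7 cells for agonist activity at Free fatty acid receptor 1 (Homo sapiens), read by scintillation counting and inositol phosphate accumulation, with a stated time of 90 min (a lower number here means that less compound is needed, a higher number that more compound is needed for the effect), compound 1 `Cc1ccc(Nc2nc(N)nc(COc3cc(N4CCCC4=O)cc(C(F)(F)F)c3)n2)cc1Cl` gives 3190 nM, compound 2 `COc1cc(OCc2nc(N)nc(Nc3ccc(C)c(Cl)c3)n2)cc(N2CCCC2=O)c1` gives 1800 nM and compound 3 `Cc1ccc(Nc2nc(N)nc(COc3cc(C#N)cc(N4CCCC4=O)c3)n2)cc1Cl` gives 4170 nM. Compound 3 has the highest number of the three, as shown by a 1.3-fold higher number from compound 1 to compound 3 (0.12 log units; within the scatter) and by a 2.3-fold higher number from compound 2 to compound 3 (0.36 log units; beyond the scatter).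

Compound 4 `Cc1ccc(Nc2nc(N)nc(COc3cc(Cl)cc(N4CCCC4=O)c3)n2)cc1Cl` carries chloro in place of cyano on an aromatic carbon. Within the data shown here, the steps that bear on this are the swaps at the same aromatic carbon: a 1.3-fold higher number from compound 1 to compound 3 (0.12 log units; within the scatter) and a 2.3-fold higher number from compound 2 to compound 3 (0.36 log units; beyond the scatter). Among the measured compounds shown here, both are small, and neither involves chloro, so there is no direct precedent. A step in this assay of a 1.5-fold lower number from compound 3 to compound 4 (0.19 log units; within the scatter) is therefore expected, with a lower number somewhat more likely than a higher one, but the step may well stay within the scatter. Compound 4 is estimated at 2700 nM, within a range from 1200 nM to 6500 nM.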

Compound 4, half-maximal effective concentration: 160 nM
Estimate against measurement, compound 4: 17-fold (1.23 log units) above; the measured number lies below the stated range.
By their numbers in this assay, from the lowest: compound 4; then compounds 2, 1 and 3 (each within the scatter of the next, the first and the last beyond it).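

In this assay this position turns out to be far more sensitive than the first three compounds suggested: among trifluoromethyl, methoxy and nitrile the largest step was modest, whereas chloro brings a 26-fold lower number from compound 3 to compound 4 (1.42 log units; beyond the scatter) and an 11-fold lower number from compound 2 to compound 4 (1.05 log units; beyond the scatter) as well as a 20-fold lower number from compound 1 to compound 4 (1.30 log units; beyond the scatter) on the same shared core. All three new steps are large and beyond the scatter, so compound 4 has the lowest number of the four and chloro stands apart from the other three groups at this aromatic carbon. The position therefore tolerates change and can also respond strongly to a single swap.

On these data alone, whether the drop is particular to chloro or extends to fluoro, bromo, methyl or an amine at this carbon stays open. Nothing measured here accounts for the size of the drop.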